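From 2-nitrobenzyl to 4-methylbenzyl in a cell toxicity test

The source may hold more compounds than are shown below. What is called first, only, known or untested is meant among the compounds shown, and "the series" means these compounds.

Measured in a toxicity assay on NIH3T3 cells (Mus musculus) for cytotoxicity, read by resazurin assay (a higher number here means that more compound is needed for the effect, a lower number that less compound is needed), so far:
Compound 1 (`COC(=O)c1ccc(NCc2cncn2Cc2cccc(C(C)(C)C)c2)cc1-c1ccccc1`) gives > 1000 nM (a limit)
Compound 2 (`COC(=O)c1ccc(NCc2cncn2Cc2ccccc2[N+](=O)[O-])cc1-c1ccccc1`) gives 10000 nM (a number)

Going by the values given here, compound 2 gives 10000 nM in this assay and is the only compound here with an actual number. Compound 1 gives > 1000 nM as a limit and not a number.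

Compound 3 (`COC(=O)c1ccc(NCc2cncn2Cc2ccc(C)cc2)cc1-c1ccccc1`) has not been measured yet. It differs from compound 2 in one place (4-methylphenyl in place of 2-nitrophenyl on a saturated chain carbon bound to an aromatic nitrogen), where 4-methylphenyl stands in place of 2-nitrophenyl on a saturated chain carbon bound to an aromatic nitrogen.

Among the compounds with values here, the only measured step (a step that the limit leaves unreadable from compound 1 to compound 2) changes this same group, but it has no readable size, so it cannot show how large a swap here should be. Compound 2 (10000 nM) therefore remains the sole anchor, and no change beyond the usual scatter is expected in this assay from this swap. The expected step (a 1.3-fold lower number from compound 2 to compound 3 (0.10 log units; within the scatter)) is small, with no firm direction. The range is kept wide for lack of any step with a readable size. The estimate for compound 3 is 8000 nM (expected range 2500 nM to 25000 nM) and the result may also come back only as a limit.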

Compound 3, half-maximal effective concentration: 50000 nM
Compound 3: the middle estimate sits 6.3-fold (0.80 log units) below what was measured; the whole stated range lies below it.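

In this assay, the position on a saturated chain carbon bound to an aromatic nitrogen now shows a step of readable size, with 4-methylphenyl in place of 2-nitrophenyl (a 5.0-fold higher number from compound 2 to compound 3 (0.70 log units; beyond the scatter)), and it lies beyond the usual scatter. So the group at this position does matter for how much compound it takes to harm these cells, and more is needed with 4-methylphenyl, although nothing here shows why; the swap replaces 2-nitrophenyl, with its 9 heavy atoms and 2 hydrogen-bond acceptors, by 4-methylphenyl, with 7 heavy atoms and 0 hydrogen-bond acceptors. Compound 1 is known only as a limit, so neither of its steps can be read: the limit of > 1000 nM in this assay, at which 1 of the 3 values shown sits.

Going by these compounds, the swap changes both the kind of group on the ring and where it sits, so it stays open which of the two carries the step, and 2-methylphenyl or 4-nitrophenyl would separate them. Also open, on these data alone, is how a plain phenyl, or a phenyl bearing a carboxylic acid or an amine, would read in this assay at this position.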